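The source may hold more compounds than are shown below. What is called first, only, known or untested is meant among the compounds shown, and "the series" means these compounds.

Measured so far:
compound 1 `O=C(NC[C@@H]1CCCc2cc(S(=O)(=O)c3cccc(F)c3)ccc21)c1ccc[nH]1`: 5.01 nM
compound 2 `O=C1CN(C[C@@H]2CCCc3cc(S(=O)(=O)c4cccc(F)c4)ccc32)CCN1`: 6.31 nM

In an assay on isolated protein for displacement of a labelled ligand from 5-hydroxytryptamine receptor 6 (Homo sapiens) (on this read-out higher numbers stand for weaker inhibition and lower numbers for stronger inhibition), compound 2 gives the higher of the two numbers, yet its nearest neighbour compound 1 sits within the scatter: a 1.3-fold higher number from compound 1 to compound 2 (0.10 log units; within the scatter). Compound 3 `CN(CC(N)=O)C[C@@H]1CCCc2cc(S(=O)(=O)c3cccc(F)c3)ccc21` differs from compound 2 by (carbamoylmethyl)(methyl)amino in place of 3-oxopiperazin-1-yl on a saturated chain carbon bound to a saturated ring carbon. Going by the values given here, the one measured step, a 1.3-fold higher number from compound 1 to compound 2 (0.10 log units; within the scatter), bears only loosely on this change, as it swapped one group for another at the same place without a clear shift in this assay. On that basis only a small step is expected in this assay, if any, with a slight lean toward a higher number. Compound 3 is expected at 12 nM (range 4 nM to 40 nM). The expected step is a 1.9-fold higher number from compound 2 to compound 3 (0.28 log units; within the scatter).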

Compound 3, inhibition constant: 1.26 nM
The estimate for compound 3 lay 9.5-fold (0.98 log units) above the measured number, and the stated range ends above it.
By their numbers in this assay, from the lowest: compound 3; then compounds 1 and 2 (each within the scatter of the next).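

In this assay, going by these compounds alone, (carbamoylmethyl)(methyl)amino in place of 3-oxopiperazin-1-yl gives a 5.0-fold lower number from compound 2 to compound 3 (0.70 log units; beyond the scatter), the first step beyond the scatter. The same group in place of ((1H-pyrrol-2-yl)carbonyl)amino gives a 4.0-fold lower number from compound 1 to compound 3 (0.60 log units; beyond the scatter), so the group on this saturated chain carbon does affect the read-out, which the earlier pair did not show. No available evidence accounts for these steps.

Still open, on these data alone, is whether the step follows from the methyl group or the carbamoylmethyl group. A dimethylamino group, a 2-carbamoylethyl chain or a carboxylic acid in place of the primary amide would help separate these.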